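Swapping the amine ring on a shared anilide core

A few compounds are considered here, and "the series" means these few. Any claim that something is new, unique, unknown or untested is made for them only; others in the source may bear on it.

Compound 1 `CC(=O)Nc1cc(Nc2cc(NC3CC3)n3ncc(C#N)c3n2)ccc1N1CCC[C@@H](N)C1` – < 1 uL/min
Compound 2 `CC(=O)Nc1cc(Nc2cc(NC3CC3)n3ncc(C#N)c3n2)ccc1N1CC[C@@H](N)C1` – 2.5 uL/min
Compound 3 `CC(=O)Nc1cc(Nc2cc(NC3CC3)n3ncc(C#N)c3n2)ccc1N1CCC[C@H](N)C1` – < 1 uL/min

Three compounds share one core and differ only in the saturated amine ring attached to the aromatic carbon. In an ADME assay on cells (Hepatocyte, Rattus norvegicus) for metabolic stability (a lower number here means slower removal, a higher number faster removal of the compound), compound 2 gives 2.5 uL/min. Compound 1 gives < 1 uL/min in this assay, which is a limit of the assay and not a number. Compound 3 likewise gives < 1 uL/min, again a limit. Among the compounds with values here, compound 2 therefore stands as the only measured number of the three; the other two sit at the limit, as noted in the limit of < 1 uL/min in this assay, at which 2 of the 3 values shown sit. The step of an at least 2.5-fold lower number from compound 2 to compound 3 (0.39 log units; beyond the scatter) and the step of an at least 2.5-fold higher number from compound 1 to compound 2 (0.39 log units; beyond the scatter) both point the same way: the six-membered ring sits lower than the five-membered one. The pair compound 1 and compound 3 differ only in configuration, as stated in the fact that compounds 1 and 3 differ only in the configuration as drawn, and both sit at the limit, so that step cannot be read.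

Compound 4 `CC(=O)Nc1cc(Nc2cc(NC3CC3)n3ncc(C#N)c3n2)ccc1N1CCC[C@@H](N(C)C)C1` is not yet measured. It differs from compound 2 by a group of 9 heavy atoms (7 carbon, 2 nitrogen; one six-membered non-aromatic ring with 1 hetero atom) in place of a group of 6 heavy atoms (4 carbon, 2 nitrogen; one five-membered non-aromatic ring with 1 hetero atom), on an aromatic carbon. Within the data shown here, the move back to a six-membered ring matches the step from compound 2 to compound 3, so a lower number is expected, though the entering group carries no hydrogen-bond donor, which none of the measured compounds tests. Compound 4 is expected to give 1.3 uL/min in this assay, within 0.5 uL/min to 4 uL/min. That estimate means an expected step of a 1.9-fold lower number from compound 2 to compound 4 (0.28 log units; within the scatter).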

Compound 4, intrinsic clearance in a liver preparation (reported as CLH), per the amount of preparation that the assay uses: < 1 uL/min
Compound 4: a limit, no number; the forecaster's own chance of this, stated with the estimate: 40%; middle value at least 1.3-fold (0.11 log units) away from the limit.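

In this assay compound 4 gives < 1 uL/min, which is a limit of the assay and not a number. The step of an at least 2.5-fold lower number from compound 2 to compound 4 (0.39 log units; beyond the scatter) shows that a six-membered ring can stay on the low side of compound 2 even when it carries dimethylamino, a group with 0 hydrogen-bond donors, so among these compounds a low reading does not depend on a free amino group. Every compound with the six-membered ring now sits at the same limit, while compound 2, the only one with the five-membered ring, gives the only number, and no compound shown goes against this pattern; the steps among compounds 1, 3 and 4 cannot be read, and the limit is what hides them: the limit of < 1 uL/min in this assay, at which 3 of the 4 values shown sit.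

The step to compound 4 changes the ring size and the amine together, so the compounds shown leave open how much belongs to each, which a dimethylamino group on the five-membered ring would separate. Also open, on these data alone, is whether the pattern holds when a hydroxyl group replaces the amine on either ring.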